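The source may report more compounds than this note shows. Statements on the series, on what has been measured and on what is new or still open speak of the compounds shown alone.

In an assay on isolated protein for inhibition of protein kinase C zeta type (Homo sapiens), with stated times of 1 h and 2.5 min, tested at 30 uM (on this read-out lower numbers stand for less inhibition and higher numbers for more inhibition at the one concentration tested (going by the name of the read-out)), compound 1 `CCOC(=O)c1c(-c2ccc(OC)c(OC)c2)csc1N` gives 100% and stands highest of the three compounds measured. Compound 3 `CCOC(=O)c1c(-c2ccc(OC)c(OC)c2)csc1NC` gives 32% in this assay, and compound 2 `CCOC(=O)c1cscc1-c1ccc(OC)c(OC)c1` gives 3%. The steps measured so far all concern the amino group on the shared core: a number 97 percentage points lower from compound 1 to compound 2 (beyond the scatter), a number 68 percentage points lower from compound 1 to compound 3 (beyond the scatter) and a number 29 percentage points higher from compound 2 to compound 3 (beyond the scatter).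

Compound 4 `COCC(C)OC(=O)c1c(-c2ccc(OC)c(OC)c2)csc1N` differs from compound 1 at a different place, the ester side chain: methoxymethyl in place of hydrogen on a saturated chain carbon bound to an oxygen next to a carbonyl group and a saturated chain carbon. Going by the values given here, no measured step touches this part of the core, so none of the recorded steps bears directly on it; the amino group that carries the large steps is kept intact in compound 4. The expectation for this assay is therefore a small step or none beyond the scatter, with a slight lean downward only because compound 1 already gives 100%, leaving no room above. The expected step is a number 15 percentage points lower from compound 1 to compound 4 (beyond the scatter), and compound 4 is estimated at 85%, within the range 50% to 100%.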

Compound 4, a percentage reported as inhibition, at one concentration (the size of the read-out at that concentration, not a potency): 49%
Beside the measured number, compound 4's estimate is 36 percentage points above it; the measured number lies below the stated range.
By their numbers in this assay, from the lowest: compound 2; then compound 3; then compound 4; then compound 1.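

In this assay, the ester side chain proves not to be a silent part of compound 1: the change from ethyl to 1-(methoxymethyl)ethyl, with the amino group left intact, gives a number 51 percentage points lower from compound 1 to compound 4 (beyond the scatter). Going by these compounds alone, all earlier steps lay on the amino group, so this is the first sign that the read-out also responds to a change on the saturated chain carbon bound to an oxygen next to a carbonyl group. Nothing available here accounts for this drop.

The compounds shown leave open whether the added methoxymethyl oxygen or the added carbon chain alone goes with the step, a question that a 1-methylethyl ester or a 2-methoxyethyl ester could address. Also open, on these data alone, is how a carboxylic acid or a primary amide in place of the ester would read in this assay.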